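Fluoro to Bromo in Compound 2

The compounds below may be only part of what the source reports. "The series", "measured", "known", "first", "only" and "open" are said of these compounds alone.

In a functional assay on OCI-Ly7 cells (Homo sapiens) for antiproliferative activity, read by WST assay, with a stated time of 3 days (on this read-out lower numbers stand for stronger inhibition and higher numbers for weaker inhibition), compound 1 `O=c1cc(I)n([C@@H]2O[C@H](CO)[C@@H](O)[C@H]2O)c(=O)[nH]1` gives > 50000 nM, which is a limit and not a number. Compound 2 `O=c1[nH]c(=O)n([C@@H]2O[C@H](CO)[C@@H](O)[C@H]2O)c(I)c1F` gives > 50000 nM, also only a limit. Compound 2 therefore stands on (the limit of > 50000 nM in this assay, at which 2 of the 3 values shown sit). Compound 3 `O=Cc1c(F)c(=O)[nH]c(=O)n1[C@@H]1O[C@H](CO)[C@@H](O)[C@H]1O` reads 600 nM.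

Compound 4 `O=c1[nH]c(=O)n([C@@H]2O[C@H](CO)[C@@H](O)[C@H]2O)c(I)c1Br` keeps the iodo group and puts bromo in place of fluoro on an aromatic carbon. Fluoro in place of hydrogen at this carbon gave a step that the two limits leave unreadable from compound 1 to compound 2. Formyl in place of iodo gave an at least 83-fold lower number from compound 2 to compound 3 (1.92 log units; beyond the scatter), but compound 4 retains the iodo. No step beyond the scatter is therefore expected in this assay, in either direction. The estimated size is a number no higher from compound 2 to compound 4 (the limit leaves the size open). For compound 4 the estimate is 50000 nM, with an expected range of 10000 nM to 100000 nM.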

Compound 4, half-maximal inhibitory concentration: > 50000 nM
Compound 4: a limit, no number; the forecaster's own chance of this, stated with the estimate: 70%; the middle value lies on the limit itself.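

Among these compounds, compound 1, compound 2 and compound 4 all give a limit and not a number, so no step among them can be read. From the compounds shown here alone, whether hydrogen, fluoro and bromo on this aromatic carbon differ at all in this assay while the iodo group stays remains open.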